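The source may report more compounds than this note shows. Statements on the series, on what has been measured and on what is new or still open speak of the compounds shown alone.

Of the compounds shown here, two have been measured in a functional assay on YAC-1 cells (Mus musculus); on this read-out higher numbers stand for larger maximal responses and lower numbers for smaller maximal responses. Compound 1, `Nc1nc(O)c2c(n1)n(C1OC(CO)[C@@H](O)[C@H]1O)c(=O)n2Cc1ccc(Cl)cc1`, gives 27% in this assay, the higher of the two numbers. Compound 2, `C=CCn1c(=O)n(C2OC(CO[Si](c3ccccc3)(c3ccccc3)C(C)(C)C)[C@@H](O)[C@H]2O)c2nc(N)nc(O)c21`, gives 15% in this assay, a number that lies below that of compound 1 by more than the usual scatter. The account now follows the step from compound 1 to compound 3, `Cn1c(=O)n(C2OC(CO)[C@@H](O)[C@H]2O)c2nc(N)nc(O)c21`. The change is hydrogen in place of 4-chlorophenyl on a saturated chain carbon bound to an aromatic nitrogen. Compound 3 differs from compound 1 only in this; compound 2 offers no direct comparison, as it differs from both in more than one place. With the 4-chlorophenyl gone, a modest step downward is expected in this assay, of a size that may just pass beyond the scatter. For compound 3 the expected value in this assay is 15%, within a range from 5% to 30%. This expectation means an estimated step of a number 12 percentage points lower from compound 1 to compound 3 (beyond the scatter) in this assay.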

Compound 3, largest response reached (reported as maximal response), in percent of the reference or control that the assay uses: 72%
Compound 3: middle estimate off by 57 percentage points, on the low side, outside the stated range (above it).
By their numbers in this assay, from the lowest: compound 2; then compound 1; then compound 3.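

In this assay, the change from 4-chlorobenzyl to methyl brings a number 45 percentage points higher from compound 1 to compound 3 (beyond the scatter), a large rise in maximal response. Within the data shown here, this gives the first direct reading of this position, as compound 2 differs from the others in more than one place, and it shows that the 4-chlorophenyl on a saturated chain carbon bound to an aromatic nitrogen is not needed for a high response in this pair: the compound without it gives the larger one. No measurement at hand explains the size or direction of this step.

The pair cannot separate the part played by the chlorine from that of the aromatic ring, so a plain benzyl group would be the telling comparison. It also leaves open how an ethyl group, a longer chain or a chain ending in an amine would stand at this place.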